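Chloro for hydrogen on two cores in one growth series

The source may hold more compounds than are shown below. What is called first, only, known or untested is meant among the compounds shown, and "the series" means these compounds.

Measured compounds:
compound 1 `COc1ccc(OC)c(-c2cc(-c3ccccc3)nn2-c2ccc(S(=O)(=O)NC(C)=O)cc2)c1` gives 15300 nM
compound 2 `COc1ccc(OC)c(-c2cc(-c3ccc(Cl)cc3)nn2-c2ccc(S(=O)(=O)NC(C)=O)cc2)c1` gives 17700 nM
compound 3 `NS(=O)(=O)c1ccc(-n2nc(-c3ccccc3)cc2-c2cc(O)ccc2O)cc1` gives 88900 nM

All three were read in a functional assay on cells (Cancer cell lines, Homo sapiens) for cytotoxicity, read by sulforhodamine B assay, with a stated time of 48 h; a higher number here means a weaker inhibitor of growth, a lower number a stronger inhibitor of growth. Compound 1 and compound 2 share one core; the change between them is chloro in place of hydrogen on an aromatic carbon, and it made the step of a 1.2-fold higher number from compound 1 to compound 2 (0.06 log units; within the scatter). Compound 3 carries a different core, and how its core differs from the core of compound 1 is not broken down here. In this assay compound 3 stands at the highest of the three numbers; compound 2 is the nearest of the other two and compound 1 the furthest, and both gaps lie beyond the scatter.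

Compound 4 `NS(=O)(=O)c1ccc(-n2nc(-c3ccc(Cl)cc3)cc2-c2cc(O)ccc2O)cc1` has not yet been measured. It differs from compound 3 by chloro in place of hydrogen on an aromatic carbon, the same change already seen within the other core, at a place described in the same words. Within the data shown here, only one measured instance of this change exists, so the expectation for compound 4 rests on a single pair. Because that pair gave a 1.2-fold higher number from compound 1 to compound 2 (0.06 log units; within the scatter), a step of similar size is expected here. For compound 4 the expected step is a 1.1-fold higher number from compound 3 to compound 4 (0.05 log units; within the scatter). Compound 4 is expected to give 100000 nM, with a range from 40000 nM to 250000 nM in this assay.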

Compound 4, concentration for 50% growth inhibition: 13000 nM
Compound 4: middle estimate off by 7.7-fold (0.89 log units), on the high side, outside the stated range (below it).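

On the core of compound 3, phenyl to 4-chlorophenyl gives a 6.8-fold lower number from compound 3 to compound 4 (0.83 log units; beyond the scatter) in this assay, so chloro in place of hydrogen on this core goes with stronger growth inhibition. The same change does not carry over from one core to the other with the same size, and a step read on the core of compound 1 gives no usable estimate for the core of compound 3: the same change on two cores in this assay, a 1.2-fold higher number (0.06 log units; within the scatter) from compound 1 to compound 2 and a 6.8-fold lower number (0.83 log units; beyond the scatter) from compound 3 to compound 4, 7.9-fold (0.90 log units) apart, beyond the scatter of two such steps. This comparison rests on a single pair on each core, so it shows that the result of this change depends on the core in these four compounds, but it does not show which feature of the two cores goes with the gap, nor whether the gap would hold for any further pair.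

Still open, from the compounds shown here alone, is whether the step on the core of compound 3 belongs to chloro itself or would also appear with another group at the same place, such as bromo, an amine or a carboxylic acid. Also open, going by these compounds, is how the step would read on a core carrying only part of the difference between the core of compound 1 and the core of compound 3, which would be needed to trace the gap to one place in the structure.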